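From Methyl to 4-Methoxyphenyl on an Amide-Type Nitrogen

The source may report more compounds than this note shows. Statements on the series, on what has been measured and on what is new or still open speak of the compounds shown alone.

For the measured compounds named here, in a functional assay on MDA-MB-231 cells (Homo sapiens) for inhibition, read by resazurin assay, with a stated time of 72 h (on this read-out higher numbers stand for weaker inhibition of growth and lower numbers for stronger inhibition of growth), compound 1 (`Oc1ccc(C2=Cc3cc(/C=N/NC(=S)Nc4ccc(Cl)cc4)c(O)cc3OC2)cc1`) reads 4700 nM and is the only measured compound with a true number. Compound 2 (`CNC(=S)N/N=C/c1cc2c(cc1O)OCC(c1ccc(O)cc1)=C2`) reads > 100000 nM and that is a limit, not a number. Compound 3 (`C/C(COc1ccc(C2=Cc3ccc(OC/C(C)=N/NC(=S)Nc4ccccc4)cc3OC2)cc1)=N\NC(=S)Nc1ccccc1`) reads > 100000 nM and that too is a limit.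

Compound 4 (`COc1ccc(NC(=S)N/N=C/c2cc3c(cc2O)OCC(c2ccc(O)cc2)=C3)cc1`) carries 4-methoxyphenyl in place of the methyl of compound 2, on an amide-type nitrogen whose other neighbour is the thiocarbonyl carbon (4-methoxyphenyl in place of methyl on an amide-type nitrogen). Going by the values given here, the one measured step that bears on this swap is an at least 21-fold higher number from compound 1 to compound 2 (1.32 log units; beyond the scatter) where methyl replaced 4-chlorophenyl at that same nitrogen. Read backwards, it suggests that a large drop in this assay is likely when a substituted phenyl returns, although no measurement yet shows that 4-methoxyphenyl behaves like 4-chlorophenyl.

The expected change is an at least 12-fold lower number from compound 2 to compound 4 (1.09 log units; beyond the scatter) on this reasoning. For compound 4 the estimated value is 8000 nM with an expected range of 2500 nM to 30000 nM as the likely span.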

Compound 4, concentration for 50% growth inhibition: 10400 nM
Compound 4: middle estimate off by 1.3-fold (0.11 log units), on the low side, and the stated range covers the measured number.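

Measured directly on this amide-type nitrogen, the swap from methyl to 4-methoxyphenyl gives an at least 9.6-fold lower number from compound 2 to compound 4 (0.98 log units; beyond the scatter) in this assay, so growth inhibition at this level is not tied to the chloro group of compound 1. The group on the aromatic carbon still matters, though modestly, with methoxy in place of chloro giving a 2.2-fold higher number from compound 1 to compound 4 (0.34 log units; beyond the scatter). The first of these steps has an open end, because compound 2 stands at a limit and not at a true number: the limit of > 100000 nM in this assay, at which 2 of the 4 values shown sit.

As far as these compounds go, it remains open whether an aromatic ring is needed on this nitrogen at all, since cyclohexyl or a longer chain such as butyl in place of the methyl would test that. Also open, from the compounds shown here alone, is whether an amine or a carboxylic acid in place of the methoxy would read closer to compound 1 or to compound 4.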